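Swapping Hydrogen for Chloro on the Phenyl of Compound 3

This account rests on a few compounds, and the source may have more. Where it says the series, first, only, none or still open, it means among the compounds named here.

Compound 3 `COc1cc(OC)c(C(=O)/C=C/c2ccccc2)c(OC)c1` gives 0.7% in a functional assay on Huh-7 cells (Homo sapiens), read by fluorescence and BrdU incorporation, with a stated time of 48 h, tested at 25 uM; a higher number here means a weaker effect of the compound at the concentration tested, a lower number a stronger effect; its number stands highest of the three, though within the scatter of both others: compound 1 `COc1cc(OC)c(C(=O)/C=C/c2ccccc2SC)c(OC)c1` gives 0.3% and compound 2 `COc1cccc(/C=C/C(=O)c2c(OC)cc(OC)cc2OC)c1` gives 0.3%. Compound 4 `COc1cc(OC)c(C(=O)/C=C/c2ccc(Cl)cc2)c(OC)c1` differs from compound 3 by chloro in place of hydrogen on an aromatic carbon. Among the compounds with values here, no measured step puts a chloro group on this ring; the nearest comparisons are a number 0.4 percentage points higher from compound 1 to compound 3 (within the scatter) and a number 0.4 percentage points higher from compound 2 to compound 3 (within the scatter), each a swap on the same ring that left the number within the scatter. Since every measured compound already sits near full effect at the tested concentration, compound 4 is expected to stay there, with a step of no change at the digits printed from compound 3 to compound 4 (within the scatter). Compound 4 is estimated at 0.7%, between 0.1% and 4%.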

Compound 4, a percentage reported as activity, at one concentration (the size of the read-out at that concentration, not a potency): 0.8%
For compound 4 the middle estimate is 0.1 percentage points below the measured one; the measured number falls inside the stated range.
By their numbers in this assay, from the lowest: compounds 1, 2, 3 and 4 (each within the scatter of the next).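

Putting a chloro group para to a large group leaves the read-out in this assay unmoved, with a number 0.1 percentage points higher from compound 3 to compound 4 (within the scatter). The comparisons with the other two compounds agree, with a number 0.5 percentage points higher from compound 2 to compound 4 (within the scatter) and a number 0.5 percentage points higher from compound 1 to compound 4 (within the scatter), so this assay does not separate 4-chlorophenyl from the other rings. No available evidence bears on this result. A single concentration at which all four compounds sit near full effect leaves any stronger or weaker effect among them at that concentration unresolved. From the compounds shown here alone, whether an amine or a carboxylic acid at this place would keep the number this low also remains open.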